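The compounds below may be only part of what the source reports. "The series", "measured", "known", "first", "only" and "open" are said of these compounds alone.

Measured compounds in an ADME assay on MT4 cells (Homo sapiens) for cytotoxicity, read by MTT assay; on this read-out higher numbers stand for lower toxicity in this test and lower numbers for higher toxicity in this test:

Compound 1 `O=[N+]([O-])c1ccc(NC(=S)OCCc2ccccn2)cc1` — > 100000 nM, a limit of the assay.
Compound 2 `S=C(Nc1ccccc1)OCCc1ccccc1` — 100000 nM.
Compound 3 `S=C(Nc1ccc(Cl)cc1)OCCc1ccccc1` — > 100000 nM, a limit of the assay.

Compound 3 stands at the upper limit of this assay; its value is a limit, not a number. Compound 1 likewise gives only a limit. Compound 2 gives a number, and that number sits at the same concentration as the limit itself, so all three values shown lie together at the top of the measured range.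

Compound 4 `O=[N+]([O-])c1ccc(NC(=S)OCCc2ccccc2)cc1` differs from compound 3 in one place: nitro in place of chloro on an aromatic carbon. A nitro group on this position is already present in compound 1, though there on a different chain; compound 1 gives only a limit, so it shows no toxicity within the range tested.

Within the data shown here, the only measured step is a number no lower from compound 2 to compound 3 (the limit leaves the size open); its size cannot be read, since compound 3 ends at the limit. The pattern of the values shown is summarised by the limit of > 100000 nM in this assay, at which 2 of the 3 values shown sit. Among the measured compounds shown here, no measured step points to any change beyond the scatter, and nothing indicates that the nitro group brings the value down into the measurable range.

Compound 4 is therefore expected to remain at or near the limit, with a number no higher from compound 3 to compound 4 (the limit leaves the size open) as the expected step. The estimate for compound 4 is 100000 nM, with a range from 50000 nM to 200000 nM, and most likely the assay will again report only a limit.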

Compound 4, half-maximal cytotoxic concentration: > 100000 nM
Compound 4: only a limit was reported (the forecaster's own chance of this, stated with the estimate: 70%); the middle value sits exactly at the limit.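

In this assay, adding a nitro group para to a large group gives a number no lower from compound 2 to compound 4 (the limit leaves the size open); this adds a second group at this position, after chloro, for which no lower number appears. The steps for nitro in place of chloro and for phenyl in place of pyridin-2-yl cannot be read, as each joins two limits, so neither change can be ranked in this test. Compound 2 is the only compound with a number rather than a limit, and the series now stays at the top of the range with both aromatic side chains: the limit of > 100000 nM in this assay, at which 3 of the 4 values shown sit.

With the values gathered at this ceiling, the compounds shown give no measurable difference in toxicity and do not reveal which structural change, if any, would bring a value into the readable range. Going by these compounds, what an amine or a carboxylic acid would do in place of nitro on this aromatic carbon remains open, as does the effect of a longer chain on the oxygen of the shared core.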